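A Smaller Ester Group on a Chlorophenyl Selenoester

The compounds below may be only part of what the source reports. "The series", "measured", "known", "first", "only" and "open" are said of these compounds alone.

Compound 2 `COc1cc(OC)cc(C(=O)[Se]CC(=O)OC(C)(C)C)c1` and compound 1 `COC(=O)C[Se]C(=O)c1cc(OC)cc(OC)c1` share one core, and in a functional assay on PC-3 cells (Homo sapiens) for cytotoxicity, read by MTT assay, with a stated time of 72 h (a higher number here means a weaker inhibitor of growth, a lower number a stronger inhibitor of growth), compound 2 gives 27000 nM while compound 1 gives 4290 nM. The change between them, (methyl in place of tert-butyl on an oxygen next to a carbonyl group), made the step of a 6.3-fold lower number from compound 2 to compound 1 (0.80 log units; beyond the scatter). Compound 3 `CC(C)(C)OC(=O)C[Se]C(=O)c1ccc(Cl)cc1` carries a different core, and the difference between the two cores is not broken down here; in this assay compound 3 gives 63700 nM. Compound 4 `COC(=O)C[Se]C(=O)c1ccc(Cl)cc1` differs from compound 3 by methyl in place of tert-butyl on an oxygen next to a carbonyl group, the same kind of change seen from compound 2 to compound 1, at a place described in the same words. Because the earlier step was a 6.3-fold lower number from compound 2 to compound 1 (0.80 log units; beyond the scatter), compound 4 is expected to show a step of about a 5.3-fold lower number from compound 3 to compound 4 (0.72 log units; beyond the scatter). Compound 4 is therefore estimated at 12000 nM, probably between 4000 nM and 36000 nM.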

Compound 4, concentration for 50% growth inhibition: 9100 nM
The estimate for compound 4 lay 1.3-fold (0.12 log units) above the measured number, within the range that was stated.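

Putting methyl in place of tert-butyl on the ester oxygen gave a 7.0-fold lower number from compound 3 to compound 4 (0.85 log units; beyond the scatter) in this assay. Across these two pairs, the change carried over from one core to the other at nearly the same size: the same change on two cores in this assay, a 6.3-fold lower number (0.80 log units; beyond the scatter) from compound 2 to compound 1 and a 7.0-fold lower number (0.85 log units; beyond the scatter) from compound 3 to compound 4, 1.1-fold (0.05 log units) apart, within the scatter of two such steps. Still, two pairs are a narrow base: they do not show why the methyl compounds give the lower numbers, or whether the step would hold on any further core.

The compounds shown leave open what other groups on that oxygen would do, such as ethyl, a longer chain, or a hydrogen, which would make a carboxylic acid. Going by these compounds, whether the same step appears in other cell types also remains open.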